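Benzyloxycarbonyl in place of cyano on a shared core

The compounds below may be only part of what the source reports. "The series", "measured", "known", "first", "only" and "open" are said of these compounds alone.

compound 1 `COc1cc(OC)c2cc(-c3ccc(OCc4ccccc4)cc3)c(O)nc2c1`: 10000 nM
compound 2 `COc1ccc(-c2cc3c(OC)cc(OC)cc3n(CC#N)c2=O)cc1`: 10000 nM

Both values come from a functional assay on PC-3 cells (Homo sapiens) for cytotoxicity, read by colorimetric assay and MTT assay; a higher number here means a weaker inhibitor, a lower number a stronger inhibitor. Compound 2, at 10000 nM, stands level with compound 1, at 10000 nM. The two differ in more than one place, so this pair does not show what any single change does.

Compound 3 `COc1ccc(-c2cc3c(OC)cc(OC)cc3n(CC(=O)OCc3ccccc3)c2=O)cc1` keeps the core of compound 2 and carries benzyloxycarbonyl in place of cyano on a saturated chain carbon bound to an aromatic nitrogen. Cut one bond further out, the same difference reads cyanomethyl to (benzyloxycarbonyl)methyl.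

For the measured compounds named here, no measured step exists to size this change. Going by the values given here, the only anchor is compound 2 at 10000 nM, and from there no shift beyond the scatter is expected in this assay, with a slight lean toward a stronger value. The expected step is a 1.3-fold lower number from compound 2 to compound 3 (0.10 log units; within the scatter). The estimate for compound 3 is 8000 nM, with an expected range from 3000 nM to 15000 nM.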

Compound 3, half-maximal inhibitory concentration: 10000 nM
Compound 3: middle estimate off by 1.3-fold (0.10 log units), on the low side, within the range that was stated.
By their numbers in this assay, from the lowest: compounds 1, 2 and 3 (each within the scatter of the next).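

In this assay, for the compounds shown here, benzyloxycarbonyl in place of cyano on a saturated chain carbon bound to an aromatic nitrogen gives no change at the digits printed from compound 2 to compound 3 (within the scatter) and is the first single change that can be read here, as compound 1 and compound 2 differ in more than one place. The position thus takes on a six-membered aromatic ring of carbon only, and trades a triple bond outside aromatic rings for a double bond, with no shift beyond the scatter in this read-out. Nothing available bears on the reason for this result.

What the compounds shown leave open is whether a different kind of group at this place, such as a carboxylic acid or an amine, would move the number away from the level shared by compound 2 and compound 3. Also open, going by these compounds, is whether a longer chain between the aromatic nitrogen and the cyano or benzyloxycarbonyl group would read any differently from the cyanomethyl and (benzyloxycarbonyl)methyl groups seen so far.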